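The source may hold more compounds than are shown below. What is called first, only, known or untested is meant among the compounds shown, and "the series" means these compounds.

Compound 1 `COc1ncc(-c2ccc3nc(NC(=O)NCC(=O)N4CCCCC4)nn3c2)cc1NS(=O)(=O)c1ccc(F)cc1`: 570 nM
Compound 2 `COc1ncc(-c2ccc3nc(NC(=O)NCCN4CCCC4)nn3c2)cc1NS(=O)(=O)c1ccc(F)cc1`: 380 nM

In a functional assay on MCF7 cells (Homo sapiens) for cytotoxicity, read by MTT assay, with a stated time of 72 h (a lower number here means a stronger inhibitor, a higher number a weaker inhibitor), compound 2 gives the lowest of the two numbers shown, though the gap to its only neighbour is within the scatter: a 1.5-fold lower number from compound 1 to compound 2 (0.18 log units; within the scatter). Compound 3 `COc1ncc(-c2ccc3nc(NC(=O)NCC(=O)N4CCCC4)nn3c2)cc1NS(=O)(=O)c1ccc(F)cc1` differs from compound 2 by (pyrrolidin-1-yl)carbonyl in place of (pyrrolidin-1-yl)methyl on a saturated chain carbon bound to an amide-type nitrogen. For the measured compounds named here, the one measured step that bears on this change swapped a (piperidin-1-yl)carbonyl for (pyrrolidin-1-yl)methyl and stayed within the scatter, so returning to a (pyrrolidin-1-yl)carbonyl is expected to shift this assay by no more than the scatter, in no clear direction. Compound 3 is estimated at 500 nM, between 250 nM and 1000 nM. The expected step is a 1.3-fold higher number from compound 2 to compound 3 (0.12 log units; within the scatter).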

Compound 3, half-maximal inhibitory concentration: 2130 nM
Estimate against measurement, compound 3: 4.3-fold (0.63 log units) below; measured number outside the range, above it.
By their numbers in this assay, from the lowest: compounds 2 and 1 (each within the scatter of the next); then compound 3.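

In this assay the group on the saturated chain carbon bound to an amide-type nitrogen does matter: (pyrrolidin-1-yl)carbonyl in place of (pyrrolidin-1-yl)methyl gives a 5.6-fold higher number from compound 2 to compound 3 (0.75 log units; beyond the scatter). Ring size on the carbonyl carbon matters as well, with pyrrolidin-1-yl in place of piperidin-1-yl giving a 3.7-fold higher number from compound 1 to compound 3 (0.57 log units; beyond the scatter). The small step between compound 1 and compound 2 therefore combined two changes that each move the number beyond the scatter when read alone in compound 3.

No measurement shown explains either step. Still open, as far as these compounds go, is how (piperidin-1-yl)methyl or a morpholin-4-yl ring would read at this place.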